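Isoquinolinyl amide in the dodecyl threonine series

The source may hold more compounds than are shown below. What is called first, only, known or untested is meant among the compounds shown, and "the series" means these compounds.

Measured so far in a functional assay on A-431 cells (Homo sapiens) for cytotoxicity, read by MTT assay, with a stated time of 48 h; on this read-out lower numbers stand for stronger inhibition and higher numbers for weaker inhibition:
compound 1 `CCCCCCCCNC(=O)[C@@H](NC(=O)c1nccc2ccccc12)[C@@H](C)O` gives 26900 nM
compound 2 `CCCCCCCCCCCCNC(=O)[C@@H](NC(=O)c1ccco1)[C@@H](C)O` gives 92400 nM
compound 3 `CCCCCCCCCCCCNC(=O)[C@@H](NC(=O)c1cccs1)[C@@H](C)O` gives 16600 nM

Compound 3 shows the lowest number of the three; the gap to compound 1 lies within the scatter, the gap to compound 2 beyond it, so compound 3 cannot be set apart from compound 1. Within the data shown here, the only step from one change, a 5.6-fold lower number from compound 2 to compound 3 (0.75 log units; beyond the scatter), concerns a different exchange of the ring and does not bear on the step below.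

Compound 4 `CCCCCCCCCCCCNC(=O)[C@@H](NC(=O)c1nccc2ccccc12)[C@@H](C)O` differs from compound 3 by isoquinolin-1-yl in place of thiophen-2-yl on a carbonyl carbon. It carries the same ring as compound 1, which differs from compound 4 only in the chain. The values of compound 1 and compound 3 lie within the scatter of each other, so for compound 4 no step beyond the scatter is expected: a 1.2-fold higher number from compound 3 to compound 4 (0.08 log units; within the scatter). Compound 4 is estimated at 20000 nM in this assay , within 8000 nM to 50000 nM.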

Compound 4, half-maximal inhibitory concentration: 62800 nM
For compound 4 the middle estimate is 3.1-fold (0.50 log units) below the measured one, outside the stated range (above it).
By their numbers in this assay, from the lowest: compounds 3 and 1 (each within the scatter of the next); then compounds 4 and 2 (each within the scatter of the next).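

Exchanging thiophen-2-yl for isoquinolin-1-yl on the carbonyl carbon gives a 3.8-fold higher number from compound 3 to compound 4 (0.58 log units; beyond the scatter) in this assay, whereas the exchange from furan-2-yl gives a 1.5-fold lower number from compound 2 to compound 4 (0.17 log units; within the scatter), so among the three dodecyl amides only thiophen-2-yl stands apart. With isoquinolin-1-yl held, the chain change gives a 2.3-fold higher number from compound 1 to compound 4 (0.37 log units; beyond the scatter), so the dodecyl chain does not bring a lower number than the octyl chain in this pair. No supporting evidence bears on either exchange.

From the compounds shown here alone, whether the chain change acts the same way with thiophen-2-yl remains open. So does the outcome for a pyridin-2-yl amide or a chain longer than dodecyl.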